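The source may report more compounds than this note shows. Statements on the series, on what has been measured and on what is new or still open speak of the compounds shown alone.

Measured compounds:
compound 1, `CCCNc1nc(NCc2ccc(C(=O)NCc3ccc(F)cc3)cc2)c2cc(C)ccc2n1`: 4400 nM
compound 2, `CNc1nc(NCc2ccc(NC(=O)c3ccc(F)cc3)cc2)c2ccccc2n1`: 1600 nM
compound 3, `CCNc1nc(NCc2ccc(C(=O)Nc3ccc(F)cc3)cc2)c2ccccc2n1`: 1900 nM

In a functional assay on HCT-116 cells (Homo sapiens) for inhibition, read by luminescence and resazurin assay, with a stated time of 3 days (a lower number here means a stronger inhibitor, a higher number a weaker inhibitor), compound 1 gives the highest of the three numbers and is thus the weakest inhibitor of the set; compound 3 lies nearest and compound 2 furthest, and both gaps go beyond the usual scatter. Compound 4, `CCCNc1nc(NCc2ccc(C(=O)Nc3ccc(Cl)nc3)cc2)c2cc(C)ccc2n1`, keeps the core of compound 1 and changes only the amide end: 6-chloropyridin-3-yl in place of 4-fluorobenzyl on an amide-type nitrogen. Compound 1 gives 4400 nM, whereas compound 3, which also carries a ring directly on the amide-type nitrogen, gives 1900 nM, so a step in this assay toward a lower number is expected, though it may not clear the scatter. The expected step from compound 1 to compound 4 is estimated at a 1.8-fold lower number from compound 1 to compound 4 (0.25 log units; within the scatter). Compound 4 is expected to give 2500 nM, with a range from 800 nM to 8000 nM.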

Compound 4, half-maximal inhibitory concentration: 1500 nM
Estimate against measurement, compound 4: 1.7-fold (0.22 log units) above, and the stated range covers the measured number.
By their numbers in this assay, from the lowest: compounds 4, 2 and 3 (each within the scatter of the next); then compound 1.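

In this assay, among the compounds shown here, this is the first pair of compounds that differ in one place, and it shows that the amide end alone can shift the result: 6-chloropyridin-3-yl in place of 4-fluorobenzyl on the amide-type nitrogen gives a 2.9-fold lower number from compound 1 to compound 4 (0.47 log units; beyond the scatter) with the core unchanged. This single swap changes the ring, its substituent and the link to the nitrogen together, so it cannot show which of these matters, and no available evidence explains the step. Open, going by these compounds, is how a pyridin-3-yl without chlorine or a 6-methoxypyridin-3-yl would compare on the same nitrogen.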